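The source may report more compounds than this note shows. Statements on the series, on what has been measured and on what is new or still open speak of the compounds shown alone.

Working notes on the series.

Compound 1, `CC(C)C(=O)OCOC(=O)N1CCN(C(=O)c2nc(Nc3cc(C4CC4)[nH]n3)c3cc(Cl)ccc3n2)C[C@H]1C`, stands highest of the three measured numbers: in an assay for inhibition of serine/threonine-protein kinase PAK 4 (Homo sapiens), read by FRET and Z'-LYTE, with a stated time of 60 min, tested at 50 uM, in the presence of a further agent that is not named here (on this read-out lower numbers stand for a weaker effect and higher numbers for a stronger effect at the one concentration tested), compound 1 gives 86.9%. Compound 2, `C[C@@H]1CN(C(=O)c2nc(Nc3cc(C4CC4)[nH]n3)c3cc(Cl)ccc3n2)CCN1C(=O)OC(C)(C)C`, gives 36.4% in this assay, and compound 3, `CC(OC(=O)N1CCN(C(=O)c2nc(Nc3cc(C4CC4)[nH]n3)c3cc(Cl)ccc3n2)C[C@H]1C)OC(=O)C(C)(C)C`, gives 65.3%. All three measured steps change the group on an oxygen next to a carbonyl group: a number 50.5 percentage points lower from compound 1 to compound 2 (beyond the scatter), a number 21.6 percentage points lower from compound 1 to compound 3 (beyond the scatter), a number 28.9 percentage points higher from compound 2 to compound 3 (beyond the scatter).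

Compound 4, `C[C@@H]1CN(C(=O)c2nc(Nc3cc(C4CC4)[nH]n3)c3cc(Cl)ccc3n2)CCN1C(=O)OCOC(=O)C(C)(C)C`, differs from compound 1 only by methyl in place of hydrogen on a saturated chain carbon bound to a carbonyl carbon and two saturated chain carbons. The step from compound 1 to compound 3 bears on it most closely, since that step carries this same change together with a further methyl on the other carbon of the chain, and it was modest. The step from compound 1 to compound 2, a much larger change of group, was large. The change to compound 4 is the smaller part of the modest one, so a small lowering in this assay, or none beyond the scatter, is expected. The expected step is a number 10.9 percentage points lower from compound 1 to compound 4 (beyond the scatter); compound 4 is estimated at 76%, with a range from 58% to 90%.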

Compound 4, a percentage reported as inhibition, at one concentration (the size of the read-out at that concentration, not a potency): 60.5%
For compound 4 the middle estimate is 15.5 percentage points above the measured one; low and high end bracket the measured number.
By their numbers in this assay, from the lowest: compound 2; then compounds 4 and 3 (each within the scatter of the next); then compound 1.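

The single methyl on a saturated chain carbon bound to a carbonyl carbon and two saturated chain carbons, turning isopropyl into tert-butyl, is not a silent change in this assay: the result is a number 26.4 percentage points lower from compound 1 to compound 4 (beyond the scatter). The methyl on the saturated chain carbon bound to two oxygens next to a carbonyl group shows no readable effect once the tert-butyl is in place, with a number 4.8 percentage points lower from compound 3 to compound 4 (within the scatter). The full ((tert-butyl)carbonyl)oxy-bearing group still stands apart from plain tert-butyl on the oxygen, with a number 24.1 percentage points higher from compound 2 to compound 4 (beyond the scatter).

No measurement at hand offers a reason for the step from isopropyl to tert-butyl. Open, from the compounds shown here alone, is how this position responds beyond these two groups, for example to a longer chain or an amine in place of the tert-butyl.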